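A hydroxyl on the sulfonyl chain: expectation for compound 3

The source may hold more compounds than are shown below. What is called first, only, known or untested is meant among the compounds shown, and "the series" means these compounds.

Measured compounds:
compound 1 `CCCc1cnc(N2CCC(C3Cc4cc(C5=CCN(S(=O)(=O)CCC)CC5)cc(F)c4O3)CC2)nc1` — 93%
compound 2 `CCCc1cnc(N2CCC(C3Cc4c(F)c(C5=CCN(S(=O)(=O)CCC)CC5)cc(F)c4O3)CC2)nc1` — 119%

In a functional assay on HEK293 cells with Glucose-dependent insulinotropic receptor (Homo sapiens) as the target, read by cAMP accumulation, with a stated time of 60 min (a lower number here means a smaller maximal response, a higher number a larger maximal response), compound 1 gives 93%, the lowest of the two numbers shown, while compound 2 gives 119%, so that a number 26 percentage points higher from compound 1 to compound 2 (beyond the scatter). Compound 3 `CCCc1cnc(N2CCC(C3Cc4cc(C5=CCN(S(=O)(=O)CCCO)CC5)cc(F)c4O3)CC2)nc1` differs from compound 1 by hydroxy in place of hydrogen on a saturated chain carbon, three bonds along the chain from a sulfonyl sulfur. For the measured compounds named here, the single measured step concerns fluoro in place of hydrogen on an aromatic carbon, a different part of the shared core, so no measured step bears on this change. For compound 3 the expectation is therefore no step beyond the scatter, with a number 3 percentage points lower from compound 1 to compound 3 (within the scatter). Compound 3 is estimated at 90%, expected between 70% and 110%.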

Compound 3, largest response reached (Emax), in percent of the reference or control that the assay uses: 92%
Estimate against measurement, compound 3: 2 percentage points below, and the stated range covers the measured number.
By their numbers in this assay, from the lowest: compounds 3 and 1 (each within the scatter of the next); then compound 2.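

In this assay, the change from propyl to 3-hydroxypropyl on the sulfonyl group gives a number 1 percentage points lower from compound 1 to compound 3 (within the scatter). The maximal response therefore does not separate these two compounds, showing that hydroxy in place of hydrogen at this chain carbon leaves this read-out unmoved, unlike the fluoro step on the aromatic carbon. Nothing available explains this result.

Going by these compounds, whether an amine, a carboxylic acid or a longer chain at this place would behave the same remains open. So does whether hydroxy would have the same outcome on compound 2.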